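The source may hold more compounds than are shown below. What is called first, only, known or untested is meant among the compounds shown, and "the series" means these compounds.

In a functional assay on cells (Homo sapiens), read by thymidine incorporation (on this read-out lower numbers stand for stronger inhibition and higher numbers for weaker inhibition), compound 1 `Brc1cnn2c(NCc3cccnc3)cc(C3CC3)nc12` gives 1500 nM and compound 2 `CCOC(=O)c1cc(NCc2cccnc2)n2ncc(Br)c2n1` gives 2900 nM with no separation beyond the scatter. Compound 3 `COc1cc(NCc2cccnc2)n2ncc(Br)c2n1` carries methoxy in place of cyclopropyl on an aromatic carbon. Going by the values given here, the one measured step bearing on this change is a 1.9-fold higher number from compound 1 to compound 2 (0.29 log units; within the scatter) and it stays within the scatter, so no step beyond the scatter is expected in this assay for compound 3. The expected step is a 1.3-fold higher number from compound 1 to compound 3 (0.12 log units; within the scatter) and it rests on that single comparison. Compound 3 is estimated at 2000 nM with an expected range from 700 nM to 6000 nM in this read-out.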

Compound 3, half-maximal inhibitory concentration: 2000 nM
Compound 3: middle estimate and measured number agree at the digits printed, and the stated range covers the measured number.
By their numbers in this assay, from the lowest: compounds 1, 3 and 2 (each within the scatter of the next).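

At this aromatic carbon in this assay, methoxy gives a 1.3-fold higher number from compound 1 to compound 3 (0.12 log units; within the scatter) and a 1.5-fold lower number from compound 2 to compound 3 (0.16 log units; within the scatter), so all three groups now lie within the scatter of one another. Methoxy has no ring and one hydrogen-bond acceptor, yet it shows no separation from cyclopropyl, and the single earlier step had not tested this change. Nothing available explains why these groups read alike.

Open, as far as these compounds go, is whether an amine, a carboxylic acid or a longer chain such as butoxy at this carbon would give a step beyond the scatter. Also open, from the compounds shown here alone, is whether this holds with the rest of the core changed.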